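One five-membered ring swapped for another

This account rests on a few compounds, and the source may have more. Where it says the series, first, only, none or still open, it means among the compounds named here.

In a functional assay on HeLa S3 cells (Homo sapiens) for cytotoxicity, read by XTT assay, with a stated time of 3 days (on this read-out higher numbers stand for weaker inhibition and lower numbers for stronger inhibition), compound 1 `OC[C@H]1O[C@@H](n2cc(F)c3c(-c4ccccc4)ncnc32)[C@H](O)[C@@H]1O` gives 2600 nM and compound 2 `OC[C@H]1O[C@@H](n2cc(F)c3c(-c4ccc[nH]4)ncnc32)[C@H](O)[C@@H]1O` gives 230 nM, the lower of the two numbers. For the measured compounds named here, the only measured step, an 11-fold lower number from compound 1 to compound 2 (1.05 log units; beyond the scatter), is large and came with 1H-pyrrol-2-yl in place of phenyl on an aromatic carbon. Compound 3 `OC[C@H]1O[C@@H](n2cc(F)c3c(-c4c[nH]cn4)ncnc32)[C@H](O)[C@@H]1O` has 1H-imidazol-4-yl in place of 1H-pyrrol-2-yl at that carbon: 1H-imidazol-4-yl in place of 1H-pyrrol-2-yl on an aromatic carbon. Going by the values given here, no measured step covers this swap, but the earlier step shows that changing this group can matter, so a moderate rise is expected. The estimated step is a 2.2-fold higher number from compound 2 to compound 3 (0.34 log units; beyond the scatter). For compound 3 the expected value is 500 nM, within an estimated range of 120 nM to 2500 nM.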

Compound 3, half-maximal inhibitory concentration: 12200 nM
Compound 3: the middle estimate sits 24-fold (1.39 log units) below what was measured, outside the stated range (above it).
By their numbers in this assay, from the lowest: compound 2; then compound 1; then compound 3.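

In this assay this position responds to which five-membered ring it carries, not merely to the presence of one: a 53-fold higher number from compound 2 to compound 3 (1.72 log units; beyond the scatter), with 1H-imidazol-4-yl bringing a second ring nitrogen and one more hydrogen-bond acceptor. A nitrogen-containing five-membered ring therefore does not guarantee a gain, as a 4.7-fold higher number from compound 1 to compound 3 (0.67 log units; beyond the scatter) runs opposite to the step to 1H-pyrrol-2-yl. Nothing available explains the difference.

The compounds shown leave open how thiophen-2-yl or furan-2-yl would compare with 1H-pyrrol-2-yl. They also leave open whether other rings at this carbon could reach lower numbers.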